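Shortening the hydroxamic acid chain on a shared core

The source may report more compounds than this note shows. Statements on the series, on what has been measured and on what is new or still open speak of the compounds shown alone.

Compound 1 `CNC(=O)CCCCCCCn1nc(-c2cnc3[nH]ccc3c2)c2c(N)ncnc21`: 15800 nM
Compound 2 `Nc1nc2cc(-c3nn(CCCCCCCCCC(=O)NO)c4ncnc(N)c34)ccc2o1`: a limit, > 50000 nM

In a functional assay on MDA-MB-231 cells (Homo sapiens) for inhibition, read by MTT assay, with a stated time of 72 h (on this read-out lower numbers stand for stronger inhibition and higher numbers for weaker inhibition), compound 1 gives 15800 nM. Compound 2 reaches a limit of this assay, > 50000 nM, and so it stands at the limit of > 50000 nM in this assay, at which 1 of the 2 values shown sits, with no number of its own. Compound 3 `Nc1nc2cc(-c3nn(CCCCCCC(=O)NO)c4ncnc(N)c34)ccc2o1` differs from compound 2 by hydroxycarbamoyl in place of 3-(hydroxycarbamoyl)propyl on a saturated chain carbon, six bonds along the chain from an aromatic nitrogen. Within the data shown here, no step between two measured compounds of this kind is available, so the direction of this change is open. The step of an at least 1.2-fold lower number from compound 2 to compound 3 (0.09 log units; that floor lies within the scatter) is expected to be small, leaving compound 3 at or near the limit. Compound 3 is therefore estimated at 40000 nM, within a range from 10000 nM to 100000 nM.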

Compound 3, half-maximal inhibitory concentration: 8430 nM
Compound 3: the middle estimate sits 4.7-fold (0.68 log units) above what was measured; measured number outside the range, below it.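

Exchanging 3-(hydroxycarbamoyl)propyl for hydroxycarbamoyl, on a saturated chain carbon, six bonds along the chain from an aromatic nitrogen, gives an at least 5.9-fold lower number from compound 2 to compound 3 (0.77 log units; beyond the scatter) in this assay. Among these compounds, this position therefore responds to chain length on the shared core, which the earlier compounds could not show. The true size of the step remains unknown because compound 2 stands at a limit: the limit of > 50000 nM in this assay, at which 1 of the 3 values shown sits.

On these data alone, whether a still shorter chain would lower the number further remains open. So does what a carboxylic acid or an amine would do in place of the hydroxycarbamoyl end.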